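The source may hold more compounds than are shown below. What is called first, only, known or untested is meant among the compounds shown, and "the series" means these compounds.

Compound 1 `CN(C(=O)c1ccc(Cl)cc1)c1ccc2[nH]c(-c3n[nH]c4ccccc34)cc2n1` and compound 2 `CN(c1ccc2[nH]c(-c3n[nH]c4ccccc34)cc2n1)S(=O)(=O)c1ccc(Br)cc1` share a core and differ only in the group on the ring nitrogen. In a functional assay on SMMC-7721 cells (Homo sapiens) for antiproliferative activity, read by MTT assay, with a stated time of 72 h (on this read-out lower numbers stand for stronger inhibition and higher numbers for weaker inhibition), compound 1 gives 2420 nM, while compound 2 gives 11500 nM. Going by the values given here, the change a 4.8-fold higher number from compound 1 to compound 2 (0.68 log units; beyond the scatter) replaces (4-chlorophenyl)carbonyl with (4-bromophenyl)sulfonyl, and on this assay compound 2 stands at the higher of the two numbers, with compound 1 as its only neighbour.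

Compound 3 `COc1ccc(S(=O)(=O)N(C)c2ccc3[nH]c(-c4n[nH]c5ccccc45)cc3n2)c(OC)c1` keeps the sulfonyl linkage of compound 2 and alters only the aryl group on it: 2,4-dimethoxyphenyl in place of 4-bromophenyl on a sulfonyl sulfur. Among the compounds with values here, no measured step changes the substitution of the aryl ring on the sulfonyl sulfur alone; the single step from compound 1 to compound 2 altered the linker and the halogen together, so it does not settle how the aryl substituents act by themselves. The expectation for compound 3 is therefore anchored on compound 2, with a step of a 1.3-fold lower number from compound 2 to compound 3 (0.11 log units; within the scatter) expected to stay within the usual scatter in either direction. Compound 3 is estimated at 9000 nM, within a range of 3000 nM to 30000 nM.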

Compound 3, half-maximal inhibitory concentration: 10800 nM
Estimate against measurement, compound 3: 1.2-fold (0.08 log units) below; low and high end bracket the measured number.
By their numbers in this assay, from the lowest: compound 1; then compounds 3 and 2 (each within the scatter of the next).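

In this assay, exchanging 4-bromophenyl for 2,4-dimethoxyphenyl on a sulfonyl sulfur gives a 1.1-fold lower number from compound 2 to compound 3 (0.03 log units; within the scatter) and so does not separate the two aryl groups at this position. Going by these compounds alone, this is the first step that alters the aryl group alone with the sulfonyl linkage held fixed, and although the entering group has 10 heavy atoms and 2 hydrogen-bond acceptors where the leaving group has 7 and 0, the numbers stay within the scatter of each other. The step of a 4.8-fold higher number from compound 1 to compound 2 (0.68 log units; beyond the scatter) remains the only one here beyond the scatter, and no measurement on hand offers an explanation for either step.

That larger step changed the linker and the halogen together. A (4-bromophenyl)carbonyl group on the same nitrogen would be needed to separate the two changes. From the compounds shown here alone, whether the position stays this flat for an aryl ring bearing an amine or a carboxylic acid, or for a longer alkyl chain on the sulfonyl sulfur, also remains open.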